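Acid replacements on the benzyl-dihydrobenzopyranol series

The compounds below may be only part of what the source reports. "The series", "measured", "known", "first", "only" and "open" are said of these compounds alone.

The shared core carries an acidic or acid-like group on the fluorophenyl ring. In a functional assay with leukotriene B4 receptor (Homo sapiens) as the target (on this read-out lower numbers stand for stronger inhibition and higher numbers for weaker inhibition), compound 1 `O=C(O)c1ccc(F)cc1-c1ccc2c(c1)OC[C@H](Cc1ccccc1)[C@H]2O` gives 5 nM; 14 nM; 5 nM (3 entries), compound 3 `O=S(=O)(Nc1ccc(F)cc1-c1ccc2c(c1)OC[C@H](Cc1ccccc1)[C@H]2O)C(F)(F)F` gives 44 nM; 15 nM (2 entries), and compound 2 `O[C@H]1c2ccc(-c3cc(F)ccc3-c3nn[nH]n3)cc2OC[C@@H]1Cc1ccccc1` gives 110 nM; for compound 2 this is the only number shown, with two further entries that report no single number. Compound 4 `NS(=O)(=O)c1ccc(F)cc1-c1ccc2c(c1)OC[C@H](Cc1ccccc1)[C@H]2O` differs from compound 2 by sulfamoyl in place of 2H-tetrazol-5-yl on an aromatic carbon. Going by the values given here, no measured step of this kind stands, so the size of the change in this assay is open; a modest loss beyond the scatter is expected from compound 2 to compound 4, namely a 1.6-fold higher number from compound 2 to compound 4 (0.21 log units; within the scatter). Compound 4 is estimated at 180 nM, within 45 nM to 700 nM.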

Compound 4, half-maximal inhibitory concentration: 17 nM
Estimate against measurement, compound 4: 11-fold (1.02 log units) above; measured number below the stated range.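

Sulfamoyl in place of 2H-tetrazol-5-yl gives a 6.5-fold lower number from compound 2 to compound 4 (0.81 log units; beyond the scatter) in this assay, so at this place a group with no ring can serve, and the aromatic five-membered ring is not required for a low number. The single entry of compound 4 lies inside the spread of the repeated entries of compound 3: the several entries of compound 3 in this assay, 44 nM; 15 nM (2 entries)

From the compounds shown here alone, whether a primary carboxamide or a methanesulfonamide at this place would hold the number stays open. So does the effect of a methyl group on the sulfamoyl nitrogen, and a single entry does not settle how compound 4 ranks against compound 3.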